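Diphenylpyridazine series: chain extension on the sulfonyl side group

The source may report more compounds than this note shows. Statements on the series, on what has been measured and on what is new or still open speak of the compounds shown alone.

Measured so far:
compound 1, `CCCCCC(=O)Nc1cc(-c2ccccc2)c(-c2ccccc2)nn1`, > 300000 nM
compound 2, `CCCCCCCSc1cc(-c2ccccc2)c(-c2ccccc2)nn1`, 76000 nM
compound 3, `CCCCCCS(=O)(=O)c1cc(-c2ccccc2)c(-c2ccccc2)nn1`, 60000 nM

In an assay on microsomes from liver for inhibition of sterol O-acyltransferase 1 (Rattus norvegicus) (a lower number here means a stronger inhibitor, a higher number a weaker inhibitor), compound 1 reaches only the limit of the assay, > 300000 nM, and gives no number. Compound 2 gives 76000 nM in this assay and compound 3 gives 60000 nM. Compound 3 thus holds the lowest of the two numbers shown, with compound 2 nearest and the pair within the scatter. The steps of an at least 3.9-fold lower number from compound 1 to compound 2 (0.59 log units; beyond the scatter) and an at least 5.0-fold lower number from compound 1 to compound 3 (0.69 log units; beyond the scatter) are both read against a limit, (the limit of > 300000 nM in this assay, at which 1 of the 3 values shown sits), so their size is a floor, not a measurement. The step of a 1.3-fold lower number from compound 2 to compound 3 (0.10 log units; within the scatter) is within the scatter.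

Compound 4, `CCCCCCCCCS(=O)(=O)c1cc(-c2ccccc2)c(-c2ccccc2)nn1`, differs from compound 3 by propyl in place of hydrogen on a saturated chain carbon, six bonds along the chain from a sulfonyl sulfur. Among the measured compounds shown here, no measured step changes the chain alone; the step from compound 2 to compound 3 swaps hexylsulfonyl for heptylsulfanyl and is within the scatter, so it gives little guidance on length. For compound 4 in this assay a change of a 1.5-fold lower number from compound 3 to compound 4 (0.18 log units; within the scatter) is expected, close to no step beyond the scatter. Compound 4 is estimated at 40000 nM, between 10000 nM and 150000 nM.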

Compound 4, half-maximal inhibitory concentration: 76000 nM
Compound 4: middle estimate off by 1.9-fold (0.28 log units), on the low side, within the range that was stated.
By their numbers in this assay, from the lowest: compounds 3, 2 and 4 (each within the scatter of the next). At a limit, above all of these: compound 1.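

In this assay, among the compounds shown here, the only step that changes the chain alone on the sulfonyl side group is a 1.3-fold higher number from compound 3 to compound 4 (0.10 log units; within the scatter). Propyl in place of hydrogen, six bonds along the chain from a sulfonyl sulfur, therefore leaves the reading indistinguishable from that of compound 3, so this position accepts the added propyl without a shift that can be told from repeat scatter, and compound 3 and compound 4 read as one level. Nothing available here bears on why the reading stays at that level.

From the compounds shown here alone, a single pair gives no trend with chain length, so it remains open whether a shorter chain such as butyl, or a longer chain than that of compound 4, would separate from this pair beyond the scatter. Also open, going by these compounds, is whether an amine or a carboxylic acid on the chain, rather than further saturated carbon, would move the number at all in this assay.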